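The compounds below may be only part of what the source reports. "The series", "measured", "known", "first", "only" and "open" are said of these compounds alone.

In a functional assay on the whole organism (Pleural cavity) with Rattus norvegicus as the target (on this read-out higher numbers stand for an effect only at larger amounts of compound and lower numbers for an effect already at smaller amounts), three compounds have been examined so far. Compound 1, `[N-]=[N+]=Nc1nccc2ncn([C@H]3C[C@H](O)[C@@H](CO)O3)c12`, gives > 9 mg/kg in this assay, a limit of the assay and not a measured number. Compound 2, `Clc1[nH]ccc2ncnc1-2`, gives > 9 mg/kg in this assay, again a limit and not a number. Compound 3, `OC[C@H]1OC(n2cnc3c(Nc4ccccc4)nccc32)[C@H](O)[C@@H]1O`, gives > 9 mg/kg in this assay, also a limit rather than a number. For the measured compounds named here, compound 2 thus stands where every value so far stands, at the limit of > 9 mg/kg in this assay, at which 3 of the 3 values shown sit, and no step between two measured numbers can be read from these data.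

Compound 4, `OCCNc1[nH]ccc2ncnc1-2`, differs from compound 2 in one place: (2-hydroxyethyl)amino in place of chloro on an aromatic carbon. Going by the values given here, nothing measured speaks for a move in either direction beyond the usual scatter; every value so far sits at the same limit, (the limit of > 9 mg/kg in this assay, at which 3 of the 3 values shown sit), and no change on the shared core has yet been seen to bring a value off it. The estimate for compound 4 in this assay is therefore 9 mg/kg, with a range from 3 mg/kg to 30 mg/kg. The step expected a number no higher from compound 2 to compound 4 (the limit leaves the size open) is no larger than the scatter, and the most likely outcome is that compound 4 will again be reported only as a limit.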

Compound 4, dose for half-maximal effect: > 9 mg/kg
Compound 4: only a limit was reported; the forecaster's own chance of this, stated with the estimate: 75%; the middle value lies on the limit itself.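

In this assay compound 4 gives > 9 mg/kg, a limit and not a number. For the compounds shown here, compound 2 is also reported only as a limit, and no step from compound 2 to compound 4 can be read. The compounds shown leave open whether any change on the shared core brings a value off the one limit they share: the limit of > 9 mg/kg in this assay, at which 4 of the 4 values shown sit.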